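Adding a bromo group to compound 3

The compounds below may be only part of what the source reports. "The series", "measured", "known", "first", "only" and "open" are said of these compounds alone.

- compound 1 `Cn1ccc2c(Oc3ccc(NC(=O)c4cc5cccnc5n(-c5ccc(Cl)cc5)c4=O)cc3)ncnc21`: 95000 nM
- compound 2 `Cn1ccc2c(Oc3ccc(NC(=O)c4cc5cccnc5n(-c5ccccc5)c4=O)cc3F)ncnc21`: 73400 nM
- compound 3 `O=C(Nc1ccc(Oc2ncnc3[nH]ccc23)c(F)c1)c1cc2cccnc2n(-c2ccccc2)c1=O`: 45000 nM

In a functional assay on MCF7 cells (Homo sapiens) for cytotoxicity, read by MTT assay, with a stated time of 72 h (on this read-out lower numbers stand for stronger inhibition and higher numbers for weaker inhibition), compound 3 gives 45000 nM. For the measured compounds named here, that number cannot be told apart from the one for compound 2, but it is lower than the one for compound 1. Compound 4 `O=C(Nc1ccc(Oc2ncnc3[nH]ccc23)c(F)c1)c1cc2cccnc2n(-c2ccc(Br)cc2)c1=O` has bromo in place of hydrogen on an aromatic carbon, para to a large group, so phenyl becomes 4-bromophenyl (bromo in place of hydrogen on an aromatic carbon). Going by the values given here, the only measured single change is of another kind, hydrogen in place of methyl on an aromatic nitrogen: a 1.6-fold lower number from compound 2 to compound 3 (0.21 log units; within the scatter). Among the compounds with values here, no measured pair shows what bromo does, so no step beyond the scatter is expected in this assay. The expected step is a 1.1-fold lower number from compound 3 to compound 4 (0.05 log units; within the scatter). For compound 4 the estimated value is 40000 nM, with an expected range of 15000 nM to 100000 nM.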

Compound 4, half-maximal inhibitory concentration: 27000 nM
The estimate for compound 4 lay 1.5-fold (0.17 log units) above the measured number; the measured number falls inside the stated range.
By their numbers in this assay, from the lowest: compounds 4, 3, 2 and 1 (each within the scatter of the next, the first and the last beyond it).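

Among the compounds shown, compound 4 is the only one that tests a change on this phenyl alone: a single bromine atom replaces hydrogen on an aromatic carbon, para to a large group. In this assay this gives a 1.7-fold lower number from compound 3 to compound 4 (0.22 log units; within the scatter), so phenyl and 4-bromophenyl cannot be told apart here. Nothing measured on these compounds offers an explanation for this result.

Still open, going by these compounds, is whether an amine or a carboxylic acid at this same position would give a step beyond the scatter.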